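A Trifluoromethyl Anilide Variant of Compound 1

A few compounds are considered here, and "the series" means these few. Any claim that something is new, unique, unknown or untested is made for them only; others in the source may bear on it.

Compound 1 `COc1cc(-c2cc(C(=O)O)c3ccccc3n2)ccc1OCC(=O)Nc1ccccc1F` gives 161000 nM in an ADME assay on HaCaT cells (Homo sapiens) for inhibition; on this read-out lower numbers stand for stronger inhibition and higher numbers for weaker inhibition.
Compound 2 `COc1cc(-c2cc(C(=O)O)c3ccccc3n2)ccc1OCC(=O)Nc1ccccc1Cl` gives 210000 nM in this assay.
Compound 3 `COc1cc(-c2cc(C(=O)O)c3ccccc3n2)ccc1OCC(=O)Nc1ccccc1C(F)(F)F` gives 102000 nM in this assay.

Among these three, compound 1 holds the second highest number; its step to compound 2 is a 1.3-fold higher number from compound 1 to compound 2 (0.12 log units; within the scatter) and its step to compound 3 is a 1.6-fold lower number from compound 1 to compound 3 (0.20 log units; within the scatter), both within the scatter. Compound 4 `COc1cc(-c2cc(C(=O)O)c3ccccc3n2)ccc1OCC(=O)Nc1ccc(C(F)(F)F)cc1` differs from compound 1 in one place: 4-(trifluoromethyl)phenyl in place of 2-fluorophenyl on an amide-type nitrogen. The step from compound 2 to compound 3, a 2.1-fold lower number from compound 2 to compound 3 (0.31 log units; beyond the scatter), is the only one beyond the scatter, and it involves the same trifluoromethyl group. Among the compounds with values here, none of the measured steps moves the group to a different position on the ring, so that part of the change rests on no data. Compound 4 is therefore expected to stay close to compound 1, with a step of a 1.3-fold lower number from compound 1 to compound 4 (0.13 log units; within the scatter) at most, giving an estimate of 120000 nM within a range from 50000 nM to 280000 nM.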

Compound 4, half-maximal inhibitory concentration: 150000 nM
Compound 4: the middle estimate sits 1.3-fold (0.10 log units) below what was measured; low and high end bracket the measured number.
By their numbers in this assay, from the lowest: compounds 3, 4, 1 and 2 (each within the scatter of the next, the first and the last beyond it).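

In this assay, within the data shown here, the step that moves the trifluoromethyl group, 4-(trifluoromethyl)phenyl in place of 2-(trifluoromethyl)phenyl on the amide-type nitrogen (a 1.5-fold higher number from compound 3 to compound 4 (0.17 log units; within the scatter)), gives the first reading on position, and it lies within the scatter. The two other steps (a 1.1-fold lower number from compound 1 to compound 4 (0.03 log units; within the scatter)) and (a 1.4-fold lower number from compound 2 to compound 4 (0.15 log units; within the scatter)) also lie within it, although the step to compound 3 from compound 2 lies beyond it. Nothing available gives a reason for these steps.

On these data alone, whether an amine or a carboxylic acid on this phenyl ring, or a longer chain in its place, would carry the number beyond the scatter remains open.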